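The source may hold more compounds than are shown below. What is called first, only, known or untested is meant among the compounds shown, and "the series" means these compounds.

Measured compounds:
- compound 1 `O=C(Nc1cc(C(F)(F)F)ccc1Nc1ccc(Br)cc1)c1ccncc1`: "not active" (no number reported) in a functional assay on Jurkat cells (Homo sapiens) for cytotoxicity, read by MTT assay, with a stated time of 48 h; on this read-out higher numbers stand for weaker inhibition and lower numbers for stronger inhibition
- compound 2 `O=C(Nc1cc(C(F)(F)F)ccc1NC1CCCCC1)c1ccncc1`: 80900 nM
- compound 3 `O=C(Nc1cc(C(F)(F)F)ccc1N1CCCC1)c1ccncc1`: "not active" (no number reported)

Compound 3 stands without a number: in this assay compound 3 is reported as "not active" (no number reported), as is compound 1, and only compound 2 gives a figure, 80900 nM. Among the measured compounds shown here, no step between measured compounds is available, so nothing is known here about the size of any change. Compound 4 `CCN(CC)c1ccc(C(F)(F)F)cc1NC(=O)c1ccncc1` differs from compound 3 by diethylamino in place of pyrrolidin-1-yl on an aromatic carbon. For the measured compounds named here, with compound 3 itself unnumbered and the one numbered neighbour weak, no shift beyond the scatter is expected in either direction; a weak or unreported result is the more likely outcome. Compound 4 is estimated at 100000 nM, in the range 30000 nM to 300000 nM.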

Compound 4, half-maximal inhibitory concentration: "not active" (no number reported)
The entry for compound 4 holds no number; the estimate stays without a comparison.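

Among the compounds shown here, with compound 3 and compound 4 both reported without a number, no step from pyrrolidin-1-yl to diethylamino can be read. The compounds shown leave open how the group at this place on the shared core relates to cytotoxicity. No evidence bearing on this result is at hand.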